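Shortening the acyl chain of compound 1

The compounds below may be only part of what the source reports. "The series", "measured", "known", "first", "only" and "open" are said of these compounds alone.

Compound 1 `CCCCCC(=O)c1c(O)c(Cl)c(O)c(Cl)c1O` was tested in a functional assay on the whole organism (S2 cells, strain S2) for inhibition, with Drosophila as the target, read by a luciferase reporter, with stated times of 1.5 h and 8 h (a higher number here means a weaker inhibitor, a lower number a stronger inhibitor), where compound 1 gives 9900 nM. Among the two numbers in hand this is the highest; the nearest is compound 2 `CCCCCC(=O)c1c(O)c(Cl)c(C)c(Cl)c1O`, which in this assay gives 3800 nM. For the measured compounds named here, the only step measured between them is a 2.6-fold lower number from compound 1 to compound 2 (0.42 log units; beyond the scatter), a methyl in place of hydroxy on an aromatic carbon.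

Compound 3 `CCCC(=O)c1c(O)c(Cl)c(O)c(Cl)c1O` is not yet measured. It differs from compound 1 by hydrogen in place of ethyl on a saturated chain carbon, three bonds along the chain from a carbonyl carbon. Going by the values given here, no measured step touches the chain: the one step available, a 2.6-fold lower number from compound 1 to compound 2 (0.42 log units; beyond the scatter), concerns the ring and says nothing about the length of the acyl chain. The change removes a short piece of the chain and nothing else, so the expectation is a step of modest size at most, with no firm direction from the data; a somewhat higher number is taken as the working guess, with a wide range to cover either direction. On that basis compound 3 is expected to give 15000 nM, within 5000 nM to 50000 nM, an expected step of a 1.5-fold higher number from compound 1 to compound 3 (0.18 log units; within the scatter).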

Compound 3, half-maximal inhibitory concentration: 21500 nM
For compound 3 the middle estimate is 1.4-fold (0.16 log units) below the measured one, within the range that was stated.
By their numbers in this assay, from the lowest: compound 2; then compound 1; then compound 3.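

Replacing ethyl with hydrogen at this place, on a saturated chain carbon, three bonds along the chain from a carbonyl carbon, gives a measurable loss in this assay (a 2.2-fold higher number from compound 1 to compound 3 (0.34 log units; beyond the scatter)). For the compounds shown here, this is the only step that touches the acyl chain, and it shows that chain length matters in this assay, with the propyl-bearing compound 3 the weaker inhibitor of the pair, a direction that the ring change in compound 2 could not indicate. No available evidence accounts for this change in the read-out.

Going by these compounds, with a single step on the chain, it remains open whether a longer chain than the pentyl of compound 1 would continue this trend or reverse it, and whether a branched chain, or an amine or a carboxylic acid carried on the chain, would be accepted at all. Also open, on these data alone, is whether the methyl of compound 2 would keep its step on the shorter chain of compound 3.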